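Solubility notes: chloro to trifluoromethyl on the aryl amide

The source may report more compounds than this note shows. Statements on the series, on what has been measured and on what is new or still open speak of the compounds shown alone.

Compound 2 `CN1CCC(C(=O)N2Cc3c(NC(=O)c4ccc(Cl)cc4)n[nH]c3C2(C)C)CC1` in a physicochemical assay for solubility, at pH 7 (on this read-out higher numbers stand for higher solubility and lower numbers for lower solubility), returns only a limit, > 225000 nM. Compound 1 `CN1CCC(C(=O)N2Cc3c(NC(=O)c4ccco4)n[nH]c3C2(C)C)CC1` in this assay likewise returns a limit, > 225000 nM. Among the compounds with values here, the one measured step, a step that the two limits leave unreadable from compound 1 to compound 2, is unreadable, since both values sit at the limit of > 225000 nM in this assay, at which 2 of the 2 values shown sit. Compound 3 `CN1CCC(C(=O)N2Cc3c(NC(=O)c4ccc(C(F)(F)F)cc4)n[nH]c3C2(C)C)CC1` differs from compound 2 by trifluoromethyl in place of chloro on an aromatic carbon. Within the data shown here, no measured step bears on this change in readable size, so no direction beyond the scatter is expected from it. For compound 3 the estimate in this assay is 200000 nM, within 50000 nM to 400000 nM, most likely again a limit. Expected accordingly: an at least 1.1-fold lower number from compound 2 to compound 3 (0.05 log units; that floor lies within the scatter).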

Compound 3, solubility: 191000 nM
Estimate against measurement, compound 3: 1.0-fold (0.02 log units) above; low and high end bracket the measured number.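

Within the data shown here, compound 3 gives 191000 nM in this assay, the only value shown that is a number and not a limit. Trifluoromethyl in place of chloro gives an at least 1.1-fold lower number from compound 2 to compound 3 (0.07 log units; that floor lies within the scatter), and 4-(trifluoromethyl)phenyl in place of furan-2-yl gives an at least 1.1-fold lower number from compound 1 to compound 3 (0.07 log units; that floor lies within the scatter). Both steps therefore show only a floor that stays within the scatter, and the step from compound 1 to compound 2 cannot be read: the limit of > 225000 nM in this assay, at which 2 of the 3 values shown sit.

As far as these compounds go, the true size of both steps stays open. Also open, from the compounds shown here alone, is how an amine or a carboxylic acid in place of trifluoromethyl on this ring would read in this assay.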